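Acyl variation on the ring nitrogen of the aminopyrimidine series

The source may hold more compounds than are shown below. What is called first, only, known or untested is meant among the compounds shown, and "the series" means these compounds.

Measured compounds:
compound 1, `CCCCNc1nc(N)nc2c1CCNC2`, 0.6 uM
compound 2, `CCCCNc1nc(N)nc2c1CN(C(C)=O)CC2`, 0.5 uM
compound 3, `CCCCNc1nc(N)nc2c1CCN(C(=O)c1ccccc1)C2`, 0.8 uM

The read-out in an assay on HEK293 cells for agonist activity at Toll-like receptor 8 (Homo sapiens), read by a luciferase reporter, with a stated time of 6 h (a lower number here means that less compound is needed, a higher number that more compound is needed for the effect), is the minimum effective concentration. Compound 2 carries the smallest number of the three, but its gaps to compound 1 and to compound 3 both lie within the usual scatter, so the three compounds are not separated by the data. Within the data shown here, the only single-point step measured so far is a 1.3-fold higher number from compound 1 to compound 3 (0.12 log units; within the scatter); it puts a large acyl group on the ring amine nitrogen and leaves the number essentially where it was. Compound 1 and compound 2 are not linked by a single listed step, but their values differ by less than the scatter.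

Compound 4, `CCCCNc1nc(N)nc2c1CN(C(=O)C(C)C)CC2`, is the next member. Compared with compound 2 the change is isopropyl in place of methyl on a carbonyl carbon. The acyl group on the ring nitrogen has so far tolerated hydrogen, acetyl and benzoyl without a shift beyond the scatter, and an isopropyl carbonyl sits between acetyl and benzoyl in size. Nothing in the measured steps points to a direction, so the expected step of a 1.2-fold higher number from compound 2 to compound 4 (0.08 log units; within the scatter) is none beyond the scatter. For compound 4 the estimated value in this assay is 0.6 uM, with a range from 0.25 uM to 1.5 uM.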

Compound 4, minimum effective concentration: 1.6 uM
The estimate for compound 4 lay 2.7-fold (0.43 log units) below the measured number, outside the stated range (above it).
By their numbers in this assay, from the lowest: compounds 2, 1, 3 and 4 (each within the scatter of the next, the first and the last beyond it).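

Within this assay isopropyl in place of methyl on a carbonyl carbon gives a 3.2-fold higher number from compound 2 to compound 4 (0.51 log units; beyond the scatter) and is the first step in the series to pass the scatter, so this position does not accept every change of acyl group without a shift, even though the step is modest and only 1 heavy atom gives way to 3. Among these compounds, the benzoyl group of compound 3 cannot be set against this result, since compound 3 is built on a core that differs from the one shared by compound 2 and compound 4, and the earlier impression of broad acyl tolerance therefore does not carry over to this core. No available evidence accounts for the shift.

A single step cannot show whether the number follows the size of the acyl group or its branching, and a straight propanoyl or butanoyl group on the core of compound 2 would separate the two. Also open, as far as these compounds go, is how a pivaloyl or cyclopropylcarbonyl group would read here, and how the free ring amine of this same core compares with compound 2.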